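Trimming tert-butyl to isopropyl in compound 2

The compounds below may be only part of what the source reports. "The series", "measured", "known", "first", "only" and "open" are said of these compounds alone.

In a functional assay on MIA PaCa-2 cells (Homo sapiens) for inhibition, read by MTT assay, with a stated time of 7 days (a lower number here means a stronger inhibitor, a higher number a weaker inhibitor), compound 1 (`CCN(CC)C(=O)c1ccc(S(=O)(=O)N2CCC[C@@H](C(=O)N3CCN(c4nc(C(C)C)no4)CC3)C2)cc1`) gives 100 nM as its half-maximal inhibitory concentration. Compound 2 (`CC(C)c1noc(N2CCN(C(=O)[C@@H]3CCCN(S(=O)(=O)c4ccc(S(=O)(=O)NC(C)(C)C)cc4)C3)CC2)n1`) gives 300 nM and holds the higher of the two numbers, which makes it the weaker inhibitor of the pair. Compound 3 (`CC(C)NS(=O)(=O)c1ccc(S(=O)(=O)N2CCC[C@@H](C(=O)N3CCN(c4nc(C(C)C)no4)CC3)C2)cc1`) departs from compound 2 by one change (hydrogen in place of methyl on a saturated chain carbon bound to two saturated chain carbons and a sulfonamide nitrogen) with hydrogen in place of methyl on a saturated chain carbon bound to two saturated chain carbons and a sulfonamide nitrogen. Going by the values given here, no measured step alters this group alone. Among the compounds with values here, the only guide is the modest step of a 3.0-fold higher number from compound 1 to compound 2 (0.48 log units; beyond the scatter) for (tert-butyl)sulfamoyl in place of diethylcarbamoyl, a larger exchange than this one. No step beyond the scatter is therefore expected in this assay and the expected step is a 1.2-fold lower number from compound 2 to compound 3 (0.08 log units; within the scatter) in size. Compound 3 is estimated at 250 nM within an expected range of 90 nM to 700 nM in all.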

Compound 3, half-maximal inhibitory concentration: 2600 nM
For compound 3 the middle estimate is 10-fold (1.02 log units) below the measured one; measured number outside the range, above it.
By their numbers in this assay, from the lowest: compound 1; then compound 2; then compound 3.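

In this assay the removal of one methyl from the tert-butyl group, on a saturated chain carbon bound to two saturated chain carbons and a sulfonamide nitrogen, gives an 8.7-fold higher number from compound 2 to compound 3 (0.94 log units; beyond the scatter) and so shows that this position responds strongly to a single carbon. The exchange of diethylcarbamoyl now also reads differently, since isopropylsulfamoyl gives a 26-fold higher number from compound 1 to compound 3 (1.41 log units; beyond the scatter) against a 3.0-fold higher number from compound 1 to compound 2 (0.48 log units; beyond the scatter) for (tert-butyl)sulfamoyl, so the outcome depends on the group on the sulfonamide nitrogen and not on the sulfamoyl group alone. Nothing measured here explains this sensitivity.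

On these data alone, it remains open whether the number rises further with ethylsulfamoyl or the unsubstituted sulfamoyl group, or whether a cyclobutyl group on that nitrogen would match tert-butyl. As far as these compounds go, whether the same methyl matters as much on another core also stays open.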